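The source may hold more compounds than are shown below. What is called first, only, known or untested is meant among the compounds shown, and "the series" means these compounds.

In a functional assay on HCC1806 cells (Homo sapiens) for inhibition, read by sulforhodamine B assay, tested at 10 uM (on this read-out lower numbers stand for less inhibition and higher numbers for more inhibition at the one concentration tested (going by the name of the read-out)), compound 3 `COC(=O)CC(=O)N1N=C(c2ccc(-n3ccnc3)cc2)CC1c1ccc(N(C)C)cc1` gives 2.1%, the highest of the three numbers measured. Compound 2 `COC(=O)CC(=O)N1N=C(c2ccc(-n3cncn3)cc2)CC1c1ccc(N(C)C)cc1` gives -7.8%, which lies within the scatter of compound 3. Going by the values given here, compound 1 `COC(=O)CC(=O)N1N=C(c2ccc(N3CCN(C)CC3)cc2)CC1c1ccc(N(C)C)cc1` gives -8.3%, and the rise a number 10.4 percentage points higher from compound 1 to compound 3 (beyond the scatter) is the only step here that reaches beyond the scatter. Compound 4 `CN(C)c1ccc(C2CC(c3ccc(-n4ccnc4)cc3)=NN2S(=O)(=O)c2ccc([N+](=O)[O-])cc2)cc1` differs from compound 3 at another place: (4-nitrophenyl)sulfonyl in place of ((methoxycarbonyl)methyl)carbonyl on an amine nitrogen in a ring. As far as these compounds go, every measured step changed the group on the aromatic carbon, so none of them bears on a change at the ring nitrogen, and the size of this step is unknown from the data. With nothing to argue otherwise, the step of a number 5.9 percentage points higher from compound 3 to compound 4 (within the scatter) is expected to stay within the scatter. Compound 4 is thus estimated at 8%, with a range from -15% to 35%.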

Compound 4, a percentage reported as inhibition, at one concentration (the size of the read-out at that concentration, not a potency): 46.6%
The estimate for compound 4 lay 38.6 percentage points below the measured number, outside the stated range (above it).
By their numbers in this assay, from the lowest: compounds 1, 2 and 3 (each within the scatter of the next, the first and the last beyond it); then compound 4.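

Putting (4-nitrophenyl)sulfonyl in place of ((methoxycarbonyl)methyl)carbonyl on the amine nitrogen in a ring gives a number 44.5 percentage points higher from compound 3 to compound 4 (beyond the scatter) in this assay, far more than any change on the aromatic carbon among compounds 1, 2 and 3. This ring nitrogen is therefore a position where the number responds strongly to the group it carries. Nothing at hand accounts for the size of this step.

The sulfonyl link and the nitro-bearing aromatic ring enter together, so a methylsulfonyl or plain phenylsulfonyl group would be needed to separate them. As far as these compounds go, whether the step holds with 4-methylpiperazin-1-yl or 1H-1,2,4-triazol-1-yl on the aromatic carbon also stays open.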